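A further amidoxime on a sulfonyl ketone core

The compounds below may be only part of what the source reports. "The series", "measured", "known", "first", "only" and "open" are said of these compounds alone.

Compound 1 `N/C(=N\O)c1ccc(C(=O)CS(=O)(=O)c2ccccc2)cc1`: in an ADME assay on THP-1 cells (Homo sapiens) for cytotoxicity, read by flow cytometry, with a stated time of 72 h (on this read-out lower numbers stand for stronger inhibition and higher numbers for weaker inhibition), compound 1 gives > 125000 nM, which is a limit of the assay and not a number.
Compound 2 `N/C(=N\O)c1ccc(S(=O)(=O)CC(=O)c2ccccc2)cc1`: in this assay compound 2 gives > 125000 nM, again a limit and not a number.

Compound 2 therefore stands at the edge of what this assay can report, and it is not alone there, because of the limit of > 125000 nM in this assay, at which 2 of the 2 values shown sit. Going by the values given here, no pair of measured compounds differs in just one place, so no measured step is available; the two values show only that neither compound 1 nor compound 2 reaches a measurable effect on these cells.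

Compound 3 `N/C(=N\O)c1ccc(C(=O)CS(=O)(=O)c2ccc(/C(N)=N/O)cc2)cc1` has not yet been measured. It differs from compound 2 by a group of 4 heavy atoms (1 carbon, 2 nitrogen, 1 oxygen; no ring) in place of a hydrogen atom, on an aromatic carbon, in words a group of 4 heavy atoms (1 carbon, 2 nitrogen, 1 oxygen; no ring) in place of a hydrogen atom, on an aromatic carbon. The new group is a second copy of the amidoxime already present on the shared core. With compound 2 sitting at the limit, no step beyond the scatter is expected from compound 2 to compound 3 in this assay, in either direction. Compound 3 is therefore expected to give about 150000 nM, with a range from 60000 nM to 400000 nM, most likely reported again only as a limit.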

Compound 3, half-maximal inhibitory concentration: > 125000 nM
Compound 3: no number, only a limit; the forecaster's own chance of this, stated with the estimate: 80%; the middle value does not contradict the limit.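

Compound 3 gives > 125000 nM in this assay, which is a limit and not a number. The steps to compound 3 from compound 1 and from compound 2 therefore cannot be read, and every value shown sits at the same edge: the limit of > 125000 nM in this assay, at which 3 of the 3 values shown sit.

On these data alone, how strongly any of these three compounds acts on the cells, and whether the second amidoxime changes that, stays open.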